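Cytotoxicity notes on chain extension in one series

The compounds below may be only part of what the source reports. "The series", "measured", "known", "first", "only" and "open" are said of these compounds alone.

Values in an ADME assay on HEL cells (Homo sapiens) for cytotoxicity, with a stated time of 3 days; a higher number here means that more compound is tolerated, a lower number that less compound is tolerated:
compound 1, `CCCc1ccc(C#Cc2cc3cn([C@H]4C[C@H](O)[C@@H](CO)O4)c(=O)nc3o2)cc1`: > 120000 nM
compound 2, `CCCCCc1ccc(C#Cc2cc3cn([C@H]4C[C@H](O)[C@@H](CO)O4)c(=O)nc3o2)cc1`: 110000 nM
compound 3, `CCCCc1ccc(-c2cc3cn([C@H]4C[C@H](O)[C@@H](CO)O4)c(=O)nc3o2)nc1`: > 50000 nM

Compound 1 gives no number in this assay; its value > 120000 nM is a limit of the assay (the limit of > 120000 nM in this assay, at which 1 of the 3 values shown sits). Compound 2 gives 110000 nM in this assay. The change from compound 1 to compound 2 is ethyl in place of hydrogen on a saturated chain carbon, three bonds along the chain from an aromatic carbon, and it produced an at least 1.0-fold lower number from compound 1 to compound 2 (0.03 log units; that floor lies within the scatter), so within this pair no effect of the added ethyl on tolerated concentration can be read.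

Compound 3 also reaches only a limit in this assay, > 50000 nM (the limit of > 50000 nM in this assay, at which 1 of the 3 values shown sits). The core of compound 3 differs from the core of compound 1 in more than one place; that difference is not broken down here.

Compound 4, `CCCCCCc1ccc(-c2cc3cn([C@H]4C[C@H](O)[C@@H](CO)O4)c(=O)nc3o2)nc1`, has not been measured in this assay. It differs from compound 3 by ethyl in place of hydrogen on a saturated chain carbon, four bonds along the chain from an aromatic carbon. This is the same kind of change as from compound 1 to compound 2, though the place is not the same: there the ethyl entered three bonds along the chain from an aromatic carbon, here four bonds along. Resting on the flat step an at least 1.0-fold lower number from compound 1 to compound 2 (0.03 log units; that floor lies within the scatter) and on the limit shown by compound 3, the step that the limit leaves unreadable from compound 3 to compound 4 is expected to stay small. Compound 4 is therefore estimated at 60000 nM in this assay, with the expected range from 25000 nM to 150000 nM, and a real chance that again only a limit is reported.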

Compound 4, half-maximal cytotoxic concentration: > 50000 nM
Compound 4: only a limit was reported (the forecaster's own chance of this, stated with the estimate: 50%); the middle value lies beyond the limit too.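

In this assay compound 4 gives > 50000 nM, which is a limit and not a number. Compound 3 ends at that same limit, so no step can be read between compound 3 and compound 4: the limit of > 50000 nM in this assay, at which 2 of the 4 values shown sit.

The compounds shown leave open whether ethyl in place of hydrogen, four bonds along the chain from an aromatic carbon, changes the tolerated concentration at all.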